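The compounds below may be only part of what the source reports. "The series", "measured", "known", "first", "only" and "open" are said of these compounds alone.

Measured so far:
compound 1 `CCOC(=O)c1c(N)sc(/N=C/c2ccc(Cl)cc2)c1C(=O)OCC` — 25200 nM
compound 2 `CCOC(=O)c1c(N)sc(/N=C/c2ccc(Br)cc2)c1C(=O)OCC` — 25900 nM

For the measured compounds named here, in a functional assay on HeLa cells (Homo sapiens) for inhibition, read by MTT assay, with a stated time of 48 h (on this read-out lower numbers stand for stronger inhibition and higher numbers for weaker inhibition), compound 1 gives 25200 nM and compound 2 gives 25900 nM; the only measured step, a 1.0-fold higher number from compound 1 to compound 2 (0.01 log units; within the scatter), is the swap of bromo for chloro, so compound 2 sits alongside compound 1 within the scatter. Compound 3 `CCOC(=O)c1c(N)sc(/N=C/c2ccco2)c1C(=O)OCC` differs from compound 2 by furan-2-yl in place of 4-bromophenyl on a carbon with a double bond to nitrogen. No measured step exchanges one ring for another, so nothing shown speaks to this change; the single halogen swap left the number essentially unmoved. Compound 3 is therefore expected to land near compound 2, with a 1.0-fold higher number from compound 2 to compound 3 (0.00 log units; within the scatter) estimated at no more than the scatter, at 26000 nM (range 10000 nM to 70000 nM).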

Compound 3, half-maximal inhibitory concentration: 46700 nM
The estimate for compound 3 lay 1.8-fold (0.25 log units) below the measured number, within the range that was stated.
By their numbers in this assay, from the lowest: compounds 1, 2 and 3 (each within the scatter of the next).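

In this assay, furan-2-yl in place of 4-bromophenyl gives (a 1.8-fold higher number from compound 2 to compound 3 (0.26 log units; within the scatter)), and furan-2-yl in place of 4-chlorophenyl gives (a 1.9-fold higher number from compound 1 to compound 3 (0.27 log units; within the scatter)). On this carbon with a double bond to nitrogen, then, even exchanging a six-membered carbon ring for a five-membered ring containing oxygen stays within the scatter, as the halogen swap did. No measurement shown offers an explanation for this.

From the compounds shown here alone, all three compounds carry an aromatic ring here, so it remains open whether any group at this place can move the number beyond the scatter. A cyclohexyl ring, or a phenyl ring bearing an amine or a carboxylic acid, would test that.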